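Aryl substitution on the shared core and cell growth inhibition

The source may hold more compounds than are shown below. What is called first, only, known or untested is meant among the compounds shown, and "the series" means these compounds.

Compound 1: `Brc1cn2ccnc2c(-c2ccc3ncn(C4CCCCC4)c3c2)n1` — 4.92%
Compound 2: `c1ccc(-c2cn3ccnc3c(-c3ccc4ncn(C5CCCCC5)c4c3)n2)cc1` — 63.9%
Compound 3: `c1cn2cc(-c3ccsc3)nc(-c3ccc4ncn(C5CCCCC5)c4c3)c2n1` — 12.1%

These three compounds were tested in a functional assay on OVCAR-8 cells (Homo sapiens) for inhibition, read by sulforhodamine B assay, with a stated time of 48 h, tested at 10 uM; a lower number here means less inhibition, a higher number more inhibition at the concentration tested (going by the name of the read-out). Compound 3 stands second highest of the three numbers; its nearest neighbour is compound 1, a step within the scatter, while compound 2 lies far above it. The change from compound 3 to compound 4, `COc1ccccc1-c1cn2ccnc2c(-c2ccc3ncn(C4CCCCC4)c3c2)n1`, is 2-methoxyphenyl in place of thiophen-3-yl on an aromatic carbon.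

Within the data shown here, two measured steps bear on this. The step of a number 59 percentage points higher from compound 1 to compound 2 (beyond the scatter) shows that a phenyl on this carbon raises inhibition strongly over bromo, and the step of a number 51.8 percentage points lower from compound 2 to compound 3 (beyond the scatter) shows that thiophen-3-yl gives far less than phenyl. Compound 4 carries a six-membered carbon-only ring like compound 2, so a large rise from compound 3 is expected, though the methoxy group leaves the size uncertain.

The estimated step is a number 32.9 percentage points higher from compound 3 to compound 4 (beyond the scatter). Compound 4 is expected to give 45%, between 15% and 75%.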

Compound 4, a percentage reported as inhibition, at one concentration (the size of the read-out at that concentration, not a potency): 8.78%
Compound 4: middle estimate off by 36.2 percentage points, on the high side, and the stated range ends above it.
By their numbers in this assay, from the lowest: compounds 1, 4 and 3 (each within the scatter of the next); then compound 2.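

In this assay the six-membered carbon-only ring alone does not carry the inhibition, since methoxy in place of hydrogen on the phenyl ring gives a large step of a number 55.1 percentage points lower from compound 2 to compound 4 (beyond the scatter) and the high number of compound 2 is not kept. The 2-methoxyphenyl group is also not told apart from the other groups at this carbon, with a step of a number 3.3 percentage points lower from compound 3 to compound 4 (within the scatter) against thiophen-3-yl and a step of a number 3.9 percentage points higher from compound 1 to compound 4 (within the scatter) against bromo, so among these four compounds only the unsubstituted phenyl stands apart. Nothing available here accounts for this loss of inhibition.

Going by these compounds, whether a fluorine, a methyl or an amine in place of that methoxy would keep the number of compound 2 stays open. On these data alone, it is also open whether a pyridine ring on this carbon would follow phenyl or thiophen-3-yl.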